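The source may report more compounds than this note shows. Statements on the series, on what has been measured and on what is new or still open speak of the compounds shown alone.

Three compounds have a result in a functional assay on A549 cells (Homo sapiens) for antiproliferative activity, read by CCK-8 assay, with a stated time of 72 h; a lower number here means a stronger inhibitor of growth, a higher number a weaker inhibitor of growth:

Compound 1 `CCC1C(=O)N(C)c2cnc(-n3ccc4cc(C(=O)NC)ccc43)nc2N1c1ccn(C)n1`, which gives 43100 nM.
Compound 2 `CC[C@@H]1C(=O)N(C)c2cnc(-n3ccc4cc(C(=O)NC(C)C)ccc43)nc2N1C1CCCC1`, which gives 1780 nM.
Compound 3 `CCC1C(=O)N(C)c2cnc(-n3ccc4cc(F)ccc43)nc2N1c1ccn(C)n1`, which is reported as "not active" (no number reported), with no number given.

Compound 2 stands with the lowest of the two numbers; the nearest, compound 1, is a step higher that lies beyond the scatter, and compound 3 is reported as not active without a figure. No pair of these compounds differs in only one place, so no single measured step can be read from them.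

Compound 4 `CCNC(=O)c1ccc2c(ccn2-c2ncc3c(n2)N(C2CCCC2)[C@H](CC)C(=O)N3C)c1` has not yet been measured in this assay. It differs from compound 2 in one place: hydrogen in place of methyl on a saturated chain carbon bound to an amide-type nitrogen and a saturated chain carbon. Cut one bond further out, the difference reads as isopropyl to ethyl on the carbamoyl group. Within the data shown here, nothing among the measured compounds shows how a change of this kind shifts this assay, and the change is small, so no step beyond the scatter is expected in either direction. For compound 4 the estimate is 2000 nM, with a range from 800 nM to 5000 nM. The expected step of a 1.1-fold higher number from compound 2 to compound 4 (0.05 log units; within the scatter) is therefore one that stays within the scatter of this assay.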

Compound 4, concentration for 50% growth inhibition: 1120 nM
Estimate against measurement, compound 4: 1.8-fold (0.25 log units) above; measured number inside the range.
By their numbers in this assay, from the lowest: compounds 4 and 2 (each within the scatter of the next); then compound 1.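

In this assay, the change from isopropylcarbamoyl to ethylcarbamoyl gives the first comparison among these compounds in which only one place differs, and it reads as a 1.6-fold lower number from compound 2 to compound 4 (0.20 log units; within the scatter). At this place, on a saturated chain carbon bound to an amide-type nitrogen and a saturated chain carbon, hydrogen can therefore stand in for methyl without a measurable shift in the read-out, and neither compound 2 nor compound 4 can be put ahead of the other. No supporting measurement accompanies this result, so it stands as an observation without an explanation.

What the compounds shown leave open is how far this holds: a longer chain such as n-butyl, a cyclopropyl ring or a carboxylic acid in place of the ethylcarbamoyl group might stay within the scatter of compound 4 or move well beyond it. A single pair also cannot tell whether the same change would behave the same way with a different group elsewhere on the shared core.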